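A few compounds are considered here, and "the series" means these few. Any claim that something is new, unique, unknown or untested is made for them only; others in the source may bear on it.

Measured in a physicochemical assay for solubility, at pH 7; a higher number here means a more soluble compound, a lower number a less soluble compound:
Compound 1 `CC1(C)c2[nH]nc(NC(=O)c3ccc(F)cc3)c2CN1C(=O)C1CCN(C2CC2)CC1`: > 225000 nM
Compound 2 `CC(C)(C)C(=O)N1Cc2c(NC(=O)c3ccc(F)cc3)n[nH]c2C1(C)C`: 235000 nM
Compound 3 `CC(=O)N1CCC(C(=O)N2Cc3c(NC(=O)c4ccc(F)cc4)n[nH]c3C2(C)C)CC1`: 204000 nM

The entry for compound 1 is a limit of the assay, not a number. Within the data shown here, compound 2 and compound 3 lie within the usual scatter of each other, so compound 2 stands level with the only other true number in this assay.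

Compound 4 `CN1CCC(C(=O)Nc2n[nH]c3c2CN(C(=O)C(C)(C)C)C3(C)C)CC1` has not yet been measured. It differs from compound 2 in one place: 1-methylpiperidin-4-yl in place of 4-fluorophenyl on a carbonyl carbon. In words, 1-methylpiperidin-4-yl stands in place of 4-fluorophenyl on a carbonyl carbon.

Three measured steps offer the nearest guide. One is a 1.2-fold lower number from compound 2 to compound 3 (0.06 log units; within the scatter). Another is an at least 1.1-fold lower number from compound 1 to compound 3 (0.04 log units; that floor lies within the scatter). The third is a step that the limit leaves unreadable from compound 1 to compound 2. None of them touches the 4-fluorophenyl, so the size of this particular swap has never been seen directly. Still, no readable step here goes beyond the scatter. The ceiling of the assay also matters: the limit of > 225000 nM in this assay, at which 1 of the 3 values shown sits. Compound 4 may therefore be reported only as a limit.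

The expected size is a 1.0-fold lower number from compound 2 to compound 4 (0.01 log units; within the scatter), which means no step beyond the scatter is expected. The estimate for compound 4 is 230000 nM, with an expected range from 170000 nM to 320000 nM.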

Compound 4, solubility: > 225000 nM
Compound 4 ended at the assay's limit; the forecaster's own chance of this, stated with the estimate: 55%; the middle value does not contradict the limit.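

In this assay compound 4 gives > 225000 nM as a limit of the assay, not a number. Among these compounds, no step from compound 2 to compound 4 can be read, because compound 4 carries this limit: the limit of > 225000 nM in this assay, at which 2 of the 4 values shown sit. The compounds shown leave open whether 1-methylpiperidin-4-yl in place of 4-fluorophenyl changes the read-out at all, and by how much.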